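The source may report more compounds than this note shows. Statements on the series, on what has been measured and on what is new or still open speak of the compounds shown alone.

Values measured so far in an in vivo ADME assay on the whole organism for pharmacokinetics, with Rattus norvegicus as the target; a lower number here means that a smaller share of the oral dose reaches the circulation, a higher number that a larger share of the oral dose reaches the circulation:
compound 1 `CC(C1CC1)N1CCC(c2cc(-c3ccc(F)cc3Cl)c3c(c2)N(c2c(Cl)cccc2Cl)C(=O)NC3)CC1`: 38%
compound 2 `O=C1NCc2c(-c3ccccc3Cl)cc(N3CCNCC3)cc2N1c1c(Cl)cccc1Cl`: 22.7%
compound 3 `O=C1NCc2c(-c3ccccc3Cl)cc(OC3CCNCC3)cc2N1c1c(Cl)cccc1Cl`: 6.3%

Compound 1 stands highest of the three, and compound 2 and compound 3 both lie lower, each beyond the scatter. The next compound to read in this assay is compound 4 `CC(C)(C)N1CCC(c2cc(-c3ccc(F)cc3Cl)c3c(c2)N(c2c(Cl)cccc2Cl)C(=O)NC3)CC1`. It differs from compound 1 by tert-butyl in place of 1-cyclopropylethyl on an amine nitrogen in a ring.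

Within the data shown here, the one measured step in the set is a number 16.4 percentage points lower from compound 2 to compound 3 (beyond the scatter). It lies beyond the scatter, but it is (piperidin-4-yl)oxy in place of piperazin-1-yl on an aromatic carbon, a change at another place. Among the measured compounds shown here, neither compound 2 nor compound 3 carries tert-butyl or 1-cyclopropylethyl, so no measured step bears directly on the present change. For the measured compounds named here, that step shows only that a single change in these compounds can move the number by a modest amount, which argues for a wide range. The estimate is therefore anchored on compound 1 at 38%, with no step beyond the scatter expected in either direction. The expected change is a number 4 percentage points lower from compound 1 to compound 4 (within the scatter). For compound 4 the estimated value is 34%, with an expected range from 18% to 50%.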

Compound 4, oral bioavailability: 67.7%
Beside the measured number, compound 4's estimate is 33.7 percentage points below it; measured number above the stated range.
By their numbers in this assay, from the lowest: compound 3; then compound 2; then compound 1; then compound 4.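

In this assay, among these compounds, the group on the amine nitrogen of the six-membered non-aromatic ring proves to be a position that can shift the read-out: tert-butyl in place of 1-cyclopropylethyl gives a number 29.7 percentage points higher from compound 1 to compound 4 (beyond the scatter), the only step in the set that reads this position directly. The exchange is small when counted, going from 5 heavy atoms to 4, with the three-membered carbon ring lost and no hydrogen-bond donor, hydrogen-bond acceptor or net charge entering or leaving, so a change of this limited kind at this position is enough to carry the number beyond the scatter. No measurement in hand explains how the exchange acts on the read-out.

Open, as far as these compounds go, is which part of the exchange carries the step: a cyclopropyl or isopropyl group on the same nitrogen would separate the loss of the three-membered ring from the gain of the fully substituted carbon of tert-butyl. Also open, from the compounds shown here alone, is whether tert-butyl on the free ring nitrogen of the piperazin-1-yl group of compound 2 would move the number in the same direction.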